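Swapping the amide substituent of compound 1: an expected drop

The source may report more compounds than this note shows. Statements on the series, on what has been measured and on what is new or still open speak of the compounds shown alone.

Measured so far:
compound 1, `CCNC(=O)/C=C1\CCc2ccc(F)cc21` — 45%
compound 2, `CNC(=O)/C=C1\CCc2ccc(Cl)cc21` — 0%
compound 3, `NC(=O)/C=C1\CCc2c(Cl)cccc21` — 35%

All three were tested in a functional assay on the whole organism with Rattus norvegicus as the target, at a dose of 20 mg/kg by the oral route; on this read-out lower numbers stand for less inhibition and higher numbers for more inhibition at the one dose given (going by the name of the read-out). Among them compound 1 shows the largest number; compound 3 lies within the usual scatter of it, so the two cannot be told apart, while compound 2 sits well beyond the scatter, far lower.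

Compound 4 is `CON(C)C(=O)/C=C1\CCc2ccc(F)cc21` and has not yet been measured in this assay. It differs from compound 1 in one place: methoxy(methyl)amino in place of ethylamino on a carbonyl carbon. The ethylamino group leaves and the methoxy(methyl)amino group enters, so the single hydrogen-bond donor on the carbonyl carbon is gone and a hydrogen-bond acceptor comes in.

Within the data shown here, no pair of measured compounds differs in only this one place, so no measured step can guide the expectation directly. The step is expected to be a number 25 percentage points lower from compound 1 to compound 4 (beyond the scatter), a fall beyond the scatter. Compound 4 is therefore estimated at 20%, with a range from 0% to 45%.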

Compound 4, a percentage reported as inhibition, in the whole organism at one dose (the size of the read-out at that dose, not a potency): 6%
Estimate against measurement, compound 4: 14 percentage points above; measured number inside the range.
By their numbers in this assay, from the lowest: compounds 2 and 4 (each within the scatter of the next); then compounds 3 and 1 (each within the scatter of the next).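

In this assay, replacing ethylamino with methoxy(methyl)amino on the carbonyl carbon gives a number 39 percentage points lower from compound 1 to compound 4 (beyond the scatter), with the rest of the molecule unchanged. Among these compounds, this is the first direct sign that the read-out is sensitive to the group at this position. However, the swap removes the hydrogen-bond donor, adds a hydrogen-bond acceptor and adds a heavy atom all at once, and a single step cannot show which of these changes matters. Nothing measured here points to a reason for the fall.

Going by these compounds, it remains open how a dimethylamino group, which also lacks the amide hydrogen but has no oxygen, would compare on the same core. A methoxyamino group, which keeps that hydrogen and carries the oxygen, or a longer chain such as propylamino, would also help to separate these changes.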